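This account rests on a few compounds, and the source may have more. Where it says the series, first, only, none or still open, it means among the compounds named here.

All four compounds share a common core and were tested in a functional assay on A375P cells (Homo sapiens) for antiproliferative activity, read by MTT assay, with a stated time of 48 h; a higher number here means a weaker inhibitor, a lower number a stronger inhibitor. Compound 1 `Nc1cccc2c(-c3cccc(NC(=O)c4ccc(C(F)(F)F)cc4C(F)(F)F)c3)ccnc12` carries a free amino group on that core. In this assay compound 1 reaches only > 20000 nM, which is a limit of the measurement and not a number. Compound 2 `CC(=O)Nc1cccc2c(-c3cccc(NC(=O)c4ccc(C(F)(F)F)cc4C(F)(F)F)c3)ccnc12` differs from compound 1 in one place: acetyl in place of hydrogen on a nitrogen on an aromatic ring. With that change compound 2 gives 10100 nM in this assay. The measured step is an at least 1.9-fold lower number from compound 1 to compound 2 (0.29 log units; that floor lies within the scatter). Since compound 1 sits at the limit of > 20000 nM in this assay, at which 1 of the 3 values shown sits, only a floor can be put on that step. Compound 3 `Cc1ccc(NC(=O)c2cc(C(F)(F)F)cc(C(F)(F)F)c2)cc1-c1ccnc2c(N)cccc12` is built on a differently arranged core; the difference between the cores of compound 1 and compound 3 is not broken down here. In this assay compound 3 gives 7400 nM, and the number for compound 2 lies within the scatter of that, so no order between the two can be read. Compound 4 `CC(=O)Nc1cccc2c(-c3cc(NC(=O)c4cc(C(F)(F)F)cc(C(F)(F)F)c4)ccc3C)ccnc12` is not yet measured. It differs from compound 3 in one place: acetyl in place of hydrogen on a nitrogen on an aromatic ring. The place is the same as in the earlier change, so this is the same change. The step from compound 3 to compound 4 is expected to be a 1.9-fold lower number from compound 3 to compound 4 (0.27 log units; within the scatter), resting on the measured step of an at least 1.9-fold lower number from compound 1 to compound 2 (0.29 log units; that floor lies within the scatter), which gives only a floor that lies within the scatter. Compound 4 is expected to give about 4000 nM in this assay, with a likely range from 1500 nM to 12000 nM.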

Compound 4, half-maximal inhibitory concentration: > 20000 nM
Compound 4: a limit, no number (the forecaster's own chance of this, stated with the estimate: 10%); middle value at least 5.0-fold (0.69 log units) away from the limit.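

In this assay compound 4 gives > 20000 nM, which is a limit of the measurement and not a number. Putting acetyl in place of hydrogen on the nitrogen gives an at least 2.7-fold higher number from compound 3 to compound 4 (0.43 log units; beyond the scatter), so on this core the change does not repeat the step seen on the core of compound 1, and its effect does not carry over unchanged from one core to the other: the same change on two cores in this assay, an at least 1.9-fold lower number (0.29 log units; that floor lies within the scatter) from compound 1 to compound 2 and an at least 2.7-fold higher number (0.43 log units; beyond the scatter) from compound 3 to compound 4, at least 5.3-fold (0.72 log units) apart, beyond the scatter of two such steps These two steps do not show why the cores differ, they offer no rule for any third core, and each gives only a floor on its size, not a full measure: the limit of > 20000 nM in this assay, at which 2 of the 4 values shown sit.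

The compounds shown leave open how either core would respond to a different group on that nitrogen, such as a methyl group, a longer chain like butanoyl, or a urea. They also leave open which of the two results is the more usual one, and the same amino to acetamido change on a third core would help to settle that.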